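Swapping a Phenyl Arm for Thiophene on a Shared Core

The compounds below may be only part of what the source reports. "The series", "measured", "known", "first", "only" and "open" are said of these compounds alone.

Measured so far:
Compound 1 `COc1ccc(-c2nc3ccccn3c2Sc2ccccc2)cc1` — in a functional assay on MDA-MB-231 cells (Homo sapiens) for inhibition, read by MTT assay, with a stated time of 48 h (on this read-out higher numbers stand for weaker inhibition and lower numbers for stronger inhibition), compound 1 gives > 100000 nM, which is a limit of the assay.
Compound 2 `CSc1ccc(-c2nc3ccccn3c2Sc2ccccc2)cc1` — compound 2 gives 23500 nM.

Among the compounds with values here, compound 2 thus has the only number in this set; the other value is a limit. Within the data shown here, the one measured step, an at least 4.2-fold lower number from compound 1 to compound 2 (0.62 log units; beyond the scatter), is methylsulfanyl in place of methoxy, so it does not touch the change made for compound 3 `c1ccc(Sc2c(-c3cccs3)nc3ccccn23)cc1`, which is thiophen-2-yl in place of 4-(methylsulfanyl)phenyl on an aromatic carbon. Among the measured compounds shown here, no measured step bears on this change, so no step beyond the scatter is expected. Compound 3 is expected at 35000 nM, between 12000 nM and 100000 nM, a step of a 1.5-fold higher number from compound 2 to compound 3 (0.17 log units; within the scatter).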

Compound 3, half-maximal inhibitory concentration: 69200 nM
The estimate for compound 3 lay 2.0-fold (0.30 log units) below the measured number, and the stated range covers the measured number.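

Thiophen-2-yl in place of 4-(methylsulfanyl)phenyl gives a 2.9-fold higher number from compound 2 to compound 3 (0.47 log units; beyond the scatter). Within the data shown here, this is the first measured sign that the group on this carbon of the shared core matters, and of these two arms the 4-(methylsulfanyl)phenyl gives the lower number. Thiophen-2-yl in place of 4-methoxyphenyl gives an at least 1.4-fold lower number from compound 1 to compound 3 (0.15 log units; that floor lies within the scatter), and that comparison rests on a limit of the assay, not a number: the limit of > 100000 nM in this assay, at which 1 of the 3 values shown sits.

Still open, going by these compounds, is how thiophen-3-yl would compare on this carbon. Also open, on these data alone, is what a phenyl ring bearing an amine or a carboxylic acid would give there.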